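This account rests on a few compounds, and the source may have more. Where it says the series, first, only, none or still open, it means among the compounds named here.

Series notes. Among the measured compounds shown here, compound 2 `CN(Cc1cccc(C(=O)O)c1)c1ccc(OCc2c(-c3c(Cl)cccc3Cl)noc2C2CC2)nc1C(F)(F)F` holds the lowest number of the three measured so far: in a functional assay on HEK293 cells for agonist activity at Bile acid receptor (Homo sapiens) (on this read-out lower numbers stand for an effect already at smaller amounts and higher numbers for an effect only at larger amounts of compound), compound 2 gives 9 nM. Compound 1 `CC(C)c1onc(-c2c(Cl)cccc2Cl)c1COc1ccc(N(C)Cc2cccc(C(=O)O)c2)c(C(F)(F)F)n1` gives 80 nM in this assay, and compound 3 `CC(C)c1onc(-c2c(Cl)cccc2Cl)c1COc1ccc(N(C)Cc2cccc(C(=O)NCCOP(=O)(O)O)c2)c(C(F)(F)F)n1` gives 457 nM. Both measured steps sit elsewhere on the shared core: an 8.9-fold lower number from compound 1 to compound 2 (0.95 log units; beyond the scatter) and a 5.7-fold higher number from compound 1 to compound 3 (0.76 log units; beyond the scatter). Compound 4 `CN(Cc1ccc(C(=O)O)cc1)c1ccc(OCc2c(-c3c(Cl)cccc3Cl)noc2C2CC2)nc1C(F)(F)F` differs from compound 2 by 4-carboxyphenyl in place of 3-carboxyphenyl on a saturated chain carbon bound to a nitrogen on an aromatic ring. For the measured compounds named here, neither measured step touches the carboxyphenyl group, so no measured step bears directly on this change, and the expectation is correspondingly loose. For compound 4 a modest rise in this assay is expected, a 2.8-fold higher number from compound 2 to compound 4 (0.44 log units; beyond the scatter), since a moved acid is not a neutral change in most series. Compound 4 is therefore estimated at 25 nM, with a range of 5 nM to 120 nM.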

Compound 4, half-maximal effective concentration: 30 nM
For compound 4 the middle estimate is 1.2-fold (0.08 log units) below the measured one; low and high end bracket the measured number.
By their numbers in this assay, from the lowest: compound 2; then compound 4; then compound 1; then compound 3.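

The carboxyphenyl group on a saturated chain carbon bound to a nitrogen on an aromatic ring now has a measured step of its own: 4-carboxyphenyl in place of 3-carboxyphenyl gives a 3.3-fold higher number from compound 2 to compound 4 (0.52 log units; beyond the scatter). The atoms are unchanged, so the attachment pattern of the acid alone moves the read-out, though compound 4 still gives 30 nM. Nothing available explains this shift.

As far as these compounds go, whether the same shift holds with isopropyl in place of cyclopropyl remains open. So does the outcome of a sulfonic acid in place of the carboxylic acid at this position.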